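The compounds below may be only part of what the source reports. "The series", "measured", "known", "first", "only" and "open" are said of these compounds alone.

Compound 1 `CCOc1ccc(-c2ccc3ncn(-c4cc(OC)c(OC)c(OC)c4)c3c2)cc1`: 2970 nM
Compound 2 `COc1cc(-n2cnc3ccc(-c4ccccc4Cl)cc32)cc(OC)c1OC`: > 10000 nM (a limit of the assay, not a number)
Compound 3 `COc1cc(-n2cnc3ccc(-c4ccc(C(C)=O)cc4)cc32)cc(OC)c1OC`: 450 nM

In a functional assay on SGC-7901 cells (Homo sapiens) for antiproliferative activity, read by MTT assay, with a stated time of 72 h (a lower number here means a stronger inhibitor, a higher number a weaker inhibitor), compound 3 gives 450 nM, the lowest actual number in this small set. Compound 4 `COc1ccc(-c2ccc3ncn(-c4cc(OC)c(OC)c(OC)c4)c3c2)cc1F` differs from it in one place: 3-fluoro-4-methoxyphenyl in place of 4-acetylphenyl on an aromatic carbon. Within the data shown here, three measured steps bear on this change. Acetyl in place of ethoxy gave a 6.6-fold lower number from compound 1 to compound 3 (0.82 log units; beyond the scatter). 4-Acetylphenyl in place of 2-chlorophenyl gave an at least 22-fold lower number from compound 2 to compound 3 (1.34 log units; beyond the scatter). 2-Chlorophenyl in place of 4-ethoxyphenyl gave an at least 3.3-fold higher number from compound 1 to compound 2 (0.52 log units; beyond the scatter). Only compound 3 carries acetyl, and compound 4 gives it up for a methoxy group, as compound 1 carries ethoxy, so a modest rise is expected in this assay. The expected change is a 4.4-fold higher number from compound 3 to compound 4 (0.65 log units; beyond the scatter). For compound 4 the estimated value is 2000 nM, with an expected range of 600 nM to 7000 nM.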

Compound 4, half-maximal inhibitory concentration: 430 nM
Estimate against measurement, compound 4: 4.7-fold (0.67 log units) above; the whole stated range lies above it.
By their numbers in this assay, from the lowest: compounds 4 and 3 (each within the scatter of the next); then compound 1. At a limit, above all of these: compound 2.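

In this assay, 3-fluoro-4-methoxyphenyl does as well as 4-acetylphenyl at this position: a 1.0-fold lower number from compound 3 to compound 4 (0.02 log units; within the scatter). An acetyl group is therefore not required for a low number here, and replacing 4-ethoxyphenyl with the fluorinated group gives a 6.9-fold lower number from compound 1 to compound 4 (0.84 log units; beyond the scatter). Measured from a limit of the assay, not a number, the step is an at least 23-fold lower number from compound 2 to compound 4 (1.36 log units; beyond the scatter).

The compounds shown leave open how much of this rests on the fluorine and how much on the methoxy group. They also leave open whether an amine or a carboxylic acid on this phenyl ring would keep the number low.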